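This account rests on a few compounds, and the source may have more. Where it says the series, first, only, none or still open, it means among the compounds named here.

Working notes on the series. Compound 1 `Cc1nc(-c2ccccc2)sc1COc1ccc(OCC(=O)O)c(F)c1` gives in an assay on CHO cells for agonist activity at Free fatty acid receptor 1 (Homo sapiens), read by FLIPR (on this read-out higher numbers stand for an effect only at larger amounts of compound and lower numbers for an effect already at smaller amounts), a value of 374 nM. Compound 2 `Cc1ccc(-c2nc(C)c(COc3ccc(OCC(=O)O)c(F)c3)s2)cc1` gives 156 nM in this assay. Among the compounds with values here, the single measured step, a 2.4-fold lower number from compound 1 to compound 2 (0.38 log units; beyond the scatter), came from a methyl entering elsewhere in compound 2 and was modest. Compound 3 `O=C(O)COc1ccc(OCc2ncc(-c3ccccc3)o2)cc1F` returns in this assay only a limit, > 10000 nM. Compound 3 therefore stands at the assay limit (the limit of > 10000 nM in this assay, at which 1 of the 3 values shown sits), without a number of its own. Compound 4 `Cc1cc(OCc2ncc(-c3ccccc3)o2)ccc1OCC(=O)O` is not yet measured and differs from compound 3 by methyl in place of fluoro on an aromatic carbon. Within the data shown here, the only step in hand, a 2.4-fold lower number from compound 1 to compound 2 (0.38 log units; beyond the scatter), adds a methyl but removes hydrogen rather than fluoro and sits on a different core, so it bears on this change only loosely. Compound 3 offers no starting number, so no direction can be read from it. Compound 4 is expected to remain near the limit, estimated at 15000 nM (3000 nM to 60000 nM). The step from compound 3 to compound 4 is expected to be a step that the limit leaves unreadable from compound 3 to compound 4, with a fair chance that compound 4 again returns only a limit.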

Compound 4, half-maximal effective concentration: > 10000 nM
Compound 4 was reported as a limit; the forecaster's own chance of this, stated with the estimate: 70%; the middle value lies beyond the limit too.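

Compound 3 and compound 4 both return only a limit in this assay, so no step can be read between them: the limit of > 10000 nM in this assay, at which 2 of the 4 values shown sit.

The compounds shown leave open what methyl in place of fluoro does on this core, where neither compound has a number of its own.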